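Adding a methyl to the amine of compound 3

The compounds below may be only part of what the source reports. "The series", "measured", "known", "first", "only" and "open" are said of these compounds alone.

For the measured compounds named here, in a functional assay on HeLa cells (Homo sapiens) for antiproliferative activity, read by MTT assay, with a stated time of 48 h (a lower number here means a stronger inhibitor, a higher number a weaker inhibitor), three compounds have measured values so far. Compound 1 (`CCNCC(=O)Nc1cc(OC)ccc1C(=O)c1ccc(OC)c2c1C=CC(C)(C)O2`) gives 4270 nM, compound 2 (`C=C(c1ccc(OC)cc1NC(=O)CO)c1ccc(OC)c2c1C=CC(C)(C)O2`) gives 100 nM, and compound 3 (`C=C(c1ccc2c(c1)C=CC(C)(C)O2)c1ccc(OC)cc1NC(=O)CNC`) gives 410 nM. Compound 3 therefore holds the middle place, with a higher number than compound 2 and a lower number than compound 1, and both gaps lie beyond the scatter.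

Compound 4 (`C=C(c1ccc2c(c1)C=CC(C)(C)O2)c1ccc(OC)cc1NC(=O)CN(C)C`) carries methyl in place of hydrogen on an amine nitrogen of compound 3: methyl in place of hydrogen on an amine nitrogen. Going by the values given here, the measured compounds differ from one another in more than one place, so no measured pair shows this change alone. The expectation therefore starts from compound 3 at 410 nM and assumes no shift beyond the scatter in either direction in this assay. The estimated step of a 1.2-fold lower number from compound 3 to compound 4 (0.07 log units; within the scatter) is expected to remain within the scatter. For compound 4 the estimated value is 350 nM, with an expected range of 100 nM to 1300 nM.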

Compound 4, half-maximal inhibitory concentration: 640 nM
The estimate for compound 4 lay 1.8-fold (0.26 log units) below the measured number, and the stated range covers the measured number.
By their numbers in this assay, from the lowest: compound 2; then compounds 3 and 4 (each within the scatter of the next); then compound 1.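

In this assay the series now has its first step that changes one place only, and going from methylamino to dimethylamino on the amine nitrogen gives a 1.6-fold higher number from compound 3 to compound 4 (0.19 log units; within the scatter) and so no separation between the two compounds. For the compounds shown here, this position therefore takes methyl in place of hydrogen on the amine nitrogen without a step beyond the scatter, a reading that the earlier compounds, which differ from one another in more than one place, could not give. Nothing on hand bears on the reason for this result.

The compounds shown leave open how this nitrogen reads with larger groups, such as a propyl chain or a piperidine ring, and as a plain amine carrying two hydrogens. From the compounds shown here alone, whether the same change reads alike on the core of compound 2 also stays open.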